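A Third Methoxy Group on the Ring at the Carbonyl

The source may hold more compounds than are shown below. What is called first, only, known or untested is meant among the compounds shown, and "the series" means these compounds.

In a functional assay on SNB-19 cells (Homo sapiens) for inhibition, read by sulforhodamine B assay, with a stated time of 48 h (a lower number here means a stronger inhibitor of growth, a higher number a weaker inhibitor of growth), three compounds have been measured. Compound 1 `COc1cc(-c2cc(/C=C/C(=O)c3ccc(N)cc3)[nH]n2)cc(OC)c1OC` gives 9980 nM. Compound 2 `COc1cc(-c2cc(/C=C/C(=O)c3ccc(Cl)c(Cl)c3)[nH]n2)cc(OC)c1OC` gives > 100000 nM, which is a limit of the assay and not a number. Compound 3 `COc1ccc(C(=O)/C=C/c2cc(-c3cc(OC)c(OC)c(OC)c3)n[nH]2)cc1OC` gives 3010 nM.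

Among the compounds with values here, compound 3 stands lowest of the two numbers; the only other number lies a modest step away, a 3.3-fold lower number from compound 1 to compound 3 (0.52 log units; beyond the scatter). Compound 4 `COc1cc(C(=O)/C=C/c2cc(-c3cc(OC)c(OC)c(OC)c3)n[nH]2)cc(OC)c1OC` differs from compound 3 by methoxy in place of hydrogen on an aromatic carbon. Within the data shown here, no measured step alters this ring in that way: the steps seen, an at least 10-fold higher number from compound 1 to compound 2 (1.00 log units; beyond the scatter) and an at least 33-fold lower number from compound 2 to compound 3 (1.52 log units; beyond the scatter), swap the whole ring on the carbonyl carbon. For compound 4 the expected step is therefore a 1.2-fold lower number from compound 3 to compound 4 (0.08 log units; within the scatter). Compound 4 is estimated at 2500 nM, between 800 nM and 8000 nM.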

Compound 4, concentration for total growth inhibition: 3690 nM
The estimate for compound 4 lay 1.5-fold (0.17 log units) below the measured number; low and high end bracket the measured number.
By their numbers in this assay, from the lowest: compounds 3 and 4 (each within the scatter of the next); then compound 1. At a limit, above all of these: compound 2.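

In this assay the step from methoxy in place of hydrogen on this aromatic carbon is a 1.2-fold higher number from compound 3 to compound 4 (0.09 log units; within the scatter) and so cannot be told from repeat-measurement noise. The earlier steps shown here swapped the whole ring on the carbonyl carbon and moved the number beyond the scatter, whereas this single added methoxy, ortho to a methoxy group, does not. Going by these compounds, whether an amine, a carboxylic acid or a longer chain such as butoxy on this same carbon would also leave the number unmoved stays open. Nothing given here accounts for this flat step.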